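Varying the Oxygen Substituent: Expectation for Compound 4

This account rests on a few compounds, and the source may have more. Where it says the series, first, only, none or still open, it means among the compounds named here.

Compound 1 `CCN(CC)C(=O)C1=C(C)NC(=O)NC1c1cccs1`: 31%
Compound 2 `CCC(CC)OC(=O)C1=C(C)NC(=O)NC1c1cccs1`: 1%
Compound 3 `CC1=C(C(=O)OC2CCCC2)C(c2cccs2)NC(=O)N1`: 1%

All three numbers come from an assay on membranes from HeLa cells for displacement of a labelled ligand from adenosine receptor A3 (Homo sapiens), read by scintillation counting, with a stated time of 180 min, tested at 1 uM; on this read-out lower numbers stand for less inhibition and higher numbers for more inhibition at the one concentration tested (going by the name of the read-out). Compound 3 sits level with compound 2 at the digits shown, and together they are the lowest of the three; compound 1 is the furthest away, as a number 30 percentage points lower from compound 1 to compound 3 (beyond the scatter) shows. Compound 4 `CC1=C(C(=O)OCC2CCC2)C(c2cccs2)NC(=O)N1` differs from compound 3 only at the oxygen next to the carbonyl group: cyclobutylmethyl in place of cyclopentyl on an oxygen next to a carbonyl group. Going by the values given here, the one measured step that bears on this is no change at the digits printed from compound 2 to compound 3 (within the scatter), which stayed within the scatter. The larger steps of a number 30 percentage points lower from compound 1 to compound 2 (beyond the scatter) and a number 30 percentage points lower from compound 1 to compound 3 (beyond the scatter) concern the diethylamino of compound 1 and do not apply here. A step of a number 1 percentage points higher from compound 3 to compound 4 (within the scatter) is therefore expected for compound 4. Compound 4 is estimated at 2%, between -8% and 12%.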

Compound 4, a percentage reported as inhibition, at one concentration (the size of the read-out at that concentration, not a potency): 1%
For compound 4 the middle estimate is 1 percentage points above the measured one, within the range that was stated.
By their numbers in this assay, from the lowest: compounds 2, 3 and 4 (each within the scatter of the next); then compound 1.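

In this assay, cyclobutylmethyl in place of cyclopentyl on an oxygen next to a carbonyl group gives no change at the digits printed from compound 3 to compound 4 (within the scatter) and so a four-membered ring reads the same as a five-membered one here. Against pentan-3-yl there is no change at the digits printed from compound 2 to compound 4 (within the scatter) as well, while a number 30 percentage points lower from compound 1 to compound 4 (beyond the scatter) leaves diethylamino on the carbonyl carbon as the only group shown that stands apart. No evidence is at hand to explain this.

On these data alone, whether an amine or a carboxylic acid carried on this oxygen would raise the number remains open. So does whether a longer chain would.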